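Anilino to benzylamino on the shared core

A few compounds are considered here, and "the series" means these few. Any claim that something is new, unique, unknown or untested is made for them only; others in the source may bear on it.

Compound 1 `O=C1C(Nc2cccc(Cl)c2)=CC(=O)c2c1nc1n2[C@H]2OC[C@@H](O)[C@H]2OC1`, compound 2 `COc1ccccc1NC1=CC(=O)c2c(nc3n2[C@H]2OC[C@@H](O)[C@H]2OC3)C1=O` and compound 3 `O=C1C(Nc2ccccc2F)=CC(=O)c2c1nc1n2[C@H]2OC[C@@H](O)[C@H]2OC1` share one core and differ only in the group on the amine nitrogen. In a functional assay on ECa-109 cells for inhibition, with ECa-109 cell line (Homo sapiens) as the target, read by sulforhodamine B assay (on this read-out lower numbers stand for stronger inhibition and higher numbers for weaker inhibition), compound 1 gives 3080 nM and compound 3 gives 2660 nM. In this assay compound 2 reaches only the assay's limit, > 4000 nM. Compound 3 holds the lowest of the two numbers, though within the scatter of compound 1 (a 1.2-fold lower number from compound 1 to compound 3 (0.06 log units; within the scatter)), and an at least 1.5-fold lower number from compound 2 to compound 3 (0.17 log units; that floor lies within the scatter) is bounded by the limit of > 4000 nM in this assay, at which 1 of the 3 values shown sits. Compound 4 `O=C1C(NCc2ccccc2)=CC(=O)c2c1nc1n2[C@H]2OC[C@@H](O)[C@H]2OC1` carries benzyl in place of 2-fluorophenyl on an amine nitrogen. For the measured compounds named here, the measured steps only exchange one substituted phenyl for another and stay within the scatter; none replaces the aryl with benzyl, so no measured step bears directly on this change. A step within the scatter, a 1.1-fold higher number from compound 3 to compound 4 (0.05 log units; within the scatter), is therefore expected. Compound 4 is estimated at 3000 nM, range 1400 nM to 6500 nM.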

Compound 4, half-maximal inhibitory concentration: > 8000 nM
Compound 4 was reported as a limit (the forecaster's own chance of this, stated with the estimate: 30%); middle value at least 2.6-fold (0.42 log units) away from the limit.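

In this assay, for the compounds shown here, a benzyl on the amine nitrogen in place of a substituted phenyl gives the only readable steps beyond the scatter in this set: an at least 3.0-fold higher number from compound 3 to compound 4 (0.47 log units; beyond the scatter) and an at least 2.5-fold higher number from compound 1 to compound 4 (0.41 log units; beyond the scatter). Compound 4 stands at a limit, not a number: the limit of > 8000 nM in this assay, at which 1 of the 4 values shown sits. The step between compound 2 and compound 4 joins two limits and cannot be read.

On these data alone, whether the ring must sit directly on the amine nitrogen remains open, as compound 4 also lacks a ring substituent. A fluorobenzyl or phenethyl group at this position would separate these two differences.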